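This account rests on a few compounds, and the source may have more. Where it says the series, first, only, none or still open, it means among the compounds named here.

Measured so far:
compound 1 `Cc1c(C(=O)N/N=C\c2cccc(O)c2O)oc2cccc(O)c12`: 12200 nM
compound 2 `COc1ccccc1/C=N\NC(=O)c1oc2cccc(O)c2c1C`: 32700 nM

Both compounds were tested in a functional assay on PC-3 cells (Homo sapiens) for inhibition; a lower number here means a stronger inhibitor, a higher number a weaker inhibitor. Within the data shown here, compound 2 gives the higher of the two numbers; its only neighbour is compound 1, and the measured step of a 2.7-fold higher number from compound 1 to compound 2 (0.43 log units; beyond the scatter) separates them. Compound 3 `Cc1c(C(=O)N/N=C\c2ccc(O)cc2O)oc2cccc(O)c12` has not yet been measured. It differs from compound 2 in one place: 2,4-dihydroxyphenyl in place of 2-methoxyphenyl on a carbon with a double bond to nitrogen. Among the measured compounds shown here, the one measured step that bears on this change is a 2.7-fold higher number from compound 1 to compound 2 (0.43 log units; beyond the scatter), in which a dihydroxyphenyl gave way to a methoxyphenyl and the number rose modestly. Here the change runs the other way, a methoxyphenyl giving way to a dihydroxyphenyl, although the second hydroxy now sits at a different place on that ring. A step of similar size back toward a stronger inhibitor is therefore expected. Compound 3 is estimated to give about 14000 nM in this assay, with a likely range from 6000 nM to 35000 nM. The expected step is a 2.3-fold lower number from compound 2 to compound 3 (0.37 log units; beyond the scatter).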

Compound 3, half-maximal inhibitory concentration: 14800 nM
Estimate against measurement, compound 3: 1.1-fold (0.02 log units) below, within the range that was stated.
By their numbers in this assay, from the lowest: compounds 1 and 3 (each within the scatter of the next); then compound 2.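

In this assay, moving the second hydroxy of the dihydroxyphenyl group, on the carbon with a double bond to nitrogen, makes no readable difference: the change from 2,3-dihydroxyphenyl to 2,4-dihydroxyphenyl gives a 1.2-fold higher number from compound 1 to compound 3 (0.08 log units; within the scatter). Among these compounds, exchanging 2-methoxyphenyl for 2,4-dihydroxyphenyl gives a 2.2-fold lower number from compound 2 to compound 3 (0.34 log units; beyond the scatter), so two different dihydroxyphenyl groups now stand apart from 2-methoxyphenyl, where earlier there was only one such comparison. Nothing measured here gives a reason for these differences.

The compounds shown leave open whether a phenyl ring with a single hydroxy would match the two dihydroxyphenyl groups or fall nearer 2-methoxyphenyl. From the compounds shown here alone, it also remains open how this number would respond to an amine or a carboxylic acid on the ring.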